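The compounds below may be only part of what the source reports. "The series", "measured", "known", "first", "only" and "open" are said of these compounds alone.

Measured so far:
- Compound 1, `COc1cc2c(Oc3ccc(NC(=O)c4cn(-c5ccccc5Cl)nn4)cc3F)ccnc2cc1OCCCN1CCC(C)CC1`: 130 nM
- Compound 2, `COc1cc2c(Oc3ccc(NC(=O)c4cn(-c5ccccc5C)nn4)cc3F)ccnc2cc1OCCCN1CCC(C)CC1`: 2380 nM

In a functional assay on HT-29 cells (Homo sapiens) for cytotoxicity, read by MTT assay, with a stated time of 72 h (on this read-out higher numbers stand for weaker inhibition and lower numbers for stronger inhibition), compound 2 gives 2380 nM, the higher of the two numbers; compound 1 gives 130 nM. For the measured compounds named here, the single measured step, an 18-fold higher number from compound 1 to compound 2 (1.26 log units; beyond the scatter), shows that the group attached to the five-membered ring nitrogen changes the read-out strongly, and that the chloro-bearing ring gave the lower number.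

Compound 3, `COc1cc2c(Oc3ccc(NC(=O)c4cn(-c5ccc(F)c(F)c5)nn4)cc3F)ccnc2cc1OCCCN1CCC(C)CC1`, differs from compound 2 by 3,4-difluorophenyl in place of 2-methylphenyl on an aromatic nitrogen. Going by the values given here, no measured step covers exactly this change. Among the compounds with values here, the only step that bears on it is an 18-fold higher number from compound 1 to compound 2 (1.26 log units; beyond the scatter), which was large; it suggests that replacing the methyl-bearing ring on this nitrogen with a halogen-bearing ring can move the number substantially, and in compound 1 the halogen-bearing ring sat at the lower end. Where the fluorines sit differs from where the chloro sat in compound 1, so the size of the shift is uncertain.

A step of a 7.9-fold lower number from compound 2 to compound 3 (0.90 log units; beyond the scatter) toward a lower number is therefore expected. Compound 3 is estimated at 300 nM, with a range from 80 nM to 1500 nM.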

Compound 3, half-maximal inhibitory concentration: 810 nM
Compound 3: middle estimate off by 2.7-fold (0.43 log units), on the low side; the range from low to high includes it.
By their numbers in this assay, from the lowest: compound 1; then compound 3; then compound 2.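

In this assay, the change on the aromatic nitrogen of the five-membered ring gives a 2.9-fold lower number from compound 2 to compound 3 (0.47 log units; beyond the scatter), so a halogen-bearing ring can lower the number without being the 2-chlorophenyl group of compound 1. That halogen-bearing ring does not fully match 2-chlorophenyl, however: the comparison gives a 6.2-fold higher number from compound 1 to compound 3 (0.79 log units; beyond the scatter), which places 3,4-difluorophenyl between the other two groups at this position, with 2-chlorophenyl lowest and 2-methylphenyl highest, and shows that the presence of halogen alone does not set the number. No supporting measurement is available to explain this order.

The step between compound 1 and compound 3 changes the kind of halogen, the number of halogens and their places on the ring all at once, so the share of each in the difference remains unresolved. Also open, as far as these compounds go, is how a plain phenyl ring, or a phenyl ring carrying a methoxy group or an amine, would compare with these three groups on the same nitrogen.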